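This account rests on a few compounds, and the source may have more. Where it says the series, first, only, none or still open, it means among the compounds named here.

Measured compounds:
Compound 1 `CCC/C=C/C(=O)N(Cc1ccc(OC)c(O)c1)c1cc(OC)c(OC)c(OC)c1` gives 95 nM in a functional assay on HCT-116 cells (Homo sapiens) for inhibition, read by MTT assay, with a stated time of 48 h; on this read-out higher numbers stand for weaker inhibition and lower numbers for stronger inhibition.
Compound 2 `COc1ccc(CN(C(=O)CCl)c2cc(OC)c(OC)c(OC)c2)cc1O` gives 250 nM in this assay.
Compound 3 `COc1ccc(CN(C(=O)CCCl)c2cc(OC)c(OC)c(OC)c2)cc1O` gives 150 nM in this assay.

Compound 3 stands second highest of the three numbers; its nearest neighbour is compound 1, and both of its steps to the other compounds are within the scatter, so no order among them can be read. The step from compound 3 to compound 4 `COc1ccc(CN(C(=O)CCCCCl)c2cc(OC)c(OC)c(OC)c2)cc1O` is 2-chloroethyl in place of chloro on a saturated chain carbon, two bonds along the chain from a carbonyl carbon. Going by the values given here, the measured step that bears on it most directly is the one between compound 2 and compound 3, where a saturated chain carbon was added to the chloro-bearing chain: a 1.7-fold lower number from compound 2 to compound 3 (0.22 log units; within the scatter). The step from compound 1 to compound 3, a 1.6-fold higher number from compound 1 to compound 3 (0.20 log units; within the scatter), and that from compound 1 to compound 2, a 2.6-fold higher number from compound 1 to compound 2 (0.42 log units; beyond the scatter), also show that all three numbers sit close together. Since the earlier chain extension stayed within the scatter, compound 4 is expected to give a number near that of compound 3, with a step of a 1.3-fold lower number from compound 3 to compound 4 (0.10 log units; within the scatter) not expected to exceed the scatter. Compound 4 is therefore estimated at 120 nM, in a range from 50 nM to 300 nM.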

Compound 4, half-maximal inhibitory concentration: 220 nM
Estimate against measurement, compound 4: 1.8-fold (0.26 log units) below; the measured number falls inside the stated range.
By their numbers in this assay, from the lowest: compounds 1, 3, 4 and 2 (each within the scatter of the next, the first and the last beyond it).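

Lengthening the chain by putting 2-chloroethyl in place of chloro, on a saturated chain carbon two bonds along the chain from a carbonyl carbon, gives a 1.5-fold higher number from compound 3 to compound 4 (0.17 log units; within the scatter) in this assay. Across the chloro-bearing chains no order can be read, since the longest and shortest also stay close (a 1.1-fold lower number from compound 2 to compound 4 (0.06 log units; within the scatter)), so this position tolerates the added length without a readable change. The 4-chlorobutyl chain also shows a modest gap from the pent-1-en-1-yl group (a 2.3-fold higher number from compound 1 to compound 4 (0.36 log units; beyond the scatter)), as the chloromethyl chain does, while the 2-chloroethyl chain goes against this pattern (a 1.6-fold higher number from compound 1 to compound 3 (0.20 log units; within the scatter)). Nothing shown accounts for these numbers.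

The compounds shown leave open whether the chlorine matters at all, as a plain butyl chain or a terminal amine or carboxylic acid in its place would test. They also leave open how a longer chain, such as 6-chlorohexyl, would read.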